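A few compounds are considered here, and "the series" means these few. Any claim that something is new, unique, unknown or untested is made for them only; others in the source may bear on it.

Compound 3 `COc1cc2c(Oc3ccc(NC(=O)c4nnn(-c5ccc(C)cc5)c4C(F)(F)F)cc3F)ccnc2cc1OCCCN1CCCC1` gives 210 nM in a functional assay on MKN-45 cells (Homo sapiens) for cytotoxicity, read by MTT assay, with a stated time of 72 h (on this read-out lower numbers stand for stronger inhibition and higher numbers for weaker inhibition), the highest of the three numbers measured. Compound 2 `COc1cc2c(Oc3ccc(NC(=O)c4nnn(-c5ccc(F)cc5)c4C(F)(F)F)cc3F)ccnc2cc1OCCCN1CCCC1` gives 21 nM and compound 1 `COc1cc2c(Oc3ccc(NC(=O)c4nnn(-c5ccccc5C(F)(F)F)c4C)cc3F)ccnc2cc1OCCCN1CCCC1` gives 70 nM in this assay. Going by the values given here, the one single-point step measured, a 10-fold higher number from compound 2 to compound 3 (1.00 log units; beyond the scatter), is the only step that directly touches compound 3. Compound 4 `COc1cc2c(Oc3ccc(NC(=O)c4nnn(-c5ccccc5C(F)(F)F)c4C(F)(F)F)cc3F)ccnc2cc1OCCCN1CCCC1` differs from compound 3 by 2-(trifluoromethyl)phenyl in place of 4-methylphenyl on an aromatic nitrogen. Compound 1 already carries this 2-(trifluoromethyl)phenyl group and sits between compound 2 and compound 3 on the numbers, so a lower number than compound 3 is expected for compound 4, and a step of a 4.2-fold lower number from compound 3 to compound 4 (0.62 log units; beyond the scatter) is estimated. Compound 4 is therefore expected to give about 50 nM in this assay, with a likely range from 12 nM to 200 nM.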

Compound 4, half-maximal inhibitory concentration: 60 nM
Compound 4: the middle estimate sits 1.2-fold (0.08 log units) below what was measured, and the stated range covers the measured number.
By their numbers in this assay, from the lowest: compound 2; then compounds 4 and 1 (each within the scatter of the next); then compound 3.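

Putting 2-(trifluoromethyl)phenyl on the aromatic nitrogen in place of 4-methylphenyl gives a 3.5-fold lower number from compound 3 to compound 4 (0.54 log units; beyond the scatter) in this assay, while in place of 4-fluorophenyl it gives a 2.9-fold higher number from compound 2 to compound 4 (0.46 log units; beyond the scatter), so this group ranks between the other two at this position. On the aromatic carbon, trifluoromethyl in place of methyl gives a 1.2-fold lower number from compound 1 to compound 4 (0.07 log units; within the scatter), so with this aryl group the two compounds cannot be told apart. Nothing available here explains these differences. Open, as far as these compounds go, is how unsubstituted phenyl or 4-aminophenyl would compare on this nitrogen, and whether swapping trifluoromethyl for methyl on the carbon would stay as small with 4-fluorophenyl.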